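Cytotoxicity limits in a shared amide series

The source may hold more compounds than are shown below. What is called first, only, known or untested is meant among the compounds shown, and "the series" means these compounds.

The series shares the core of compound 2 `COc1ccc(-c2cnc(NC(=O)c3ccccc3F)n2C)cc1`, which bears a 2-fluorophenyl on the carbonyl carbon. In a toxicity assay on THP-1 cells (Homo sapiens) for inhibition (a higher number here means that more compound is tolerated, a lower number that less compound is tolerated), compound 2 gives > 100000 nM, a limit of the assay and not a number. Compound 1 `COc1ccc(-c2cnc(NC(=O)c3cccc(C#N)c3)n2C)cc1` carries a 3-cyanophenyl in the same place. In this assay compound 1 gives > 100000 nM, again a limit. The step that the two limits leave unreadable from compound 1 to compound 2 is left unreadable by the two limits. Compound 3 `Cn1c(-c2ccccc2)cnc1NC(=O)c1cccc(Cl)c1` differs from compound 2 in more than one place. In this assay compound 3 gives > 50000 nM, also a limit. Within the data shown here, all three values of the series so far sit at limits: the limit of > 100000 nM in this assay, at which 2 of the 3 values shown sit, and (the limit of > 50000 nM in this assay, at which 1 of the 3 values shown sits).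

Compound 4 `COc1ccc(-c2cnc(NC(=O)c3ccccc3Cl)n2C)cc1` is still to be measured. Against compound 2 the change is chloro in place of fluoro on an aromatic carbon. Among the measured compounds shown here, no measured step bears on it as a number; the single one-place step is unreadable, and nothing among the three compounds shows a readable effect in this assay. The expected step of a number no higher from compound 2 to compound 4 (the limit leaves the size open) is accordingly none beyond the scatter, with a result again most likely at the limit. Compound 4 is estimated at 100000 nM, in the range 50000 nM to 300000 nM.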

Compound 4, half-maximal cytotoxic concentration: > 50000 nM
Compound 4: only a limit was reported (the forecaster's own chance of this, stated with the estimate: 85%); the middle value is on the limit's open side.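

Compound 4 gives only a limit in this assay, as do compound 1 and compound 2, so the steps from compound 2 to compound 4 and from compound 1 to compound 4 cannot be read. The compounds shown leave open whether any change to the group on the carbonyl carbon shifts the tolerated concentration at all.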